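A few compounds are considered here, and "the series" means these few. Any claim that something is new, unique, unknown or untested is made for them only; others in the source may bear on it.

Among the compounds with values here, in an assay on isolated protein for inhibition of receptor-type tyrosine-protein phosphatase C (Homo sapiens), read by spectrophotometry (a lower number here means a stronger inhibitor, a higher number a weaker inhibitor), compound 3 `Cc1ccc(S(=O)(=O)NNC(=O)COc2ccc3cc(C(O)(C(F)(F)F)C(F)(F)F)c(O)cc3c2)cc1` gives 16100 nM, the only plain number among the three measured compounds. Compound 1 `CCN(CC)C(=O)COc1ccc2cc(C(O)(C(F)(F)F)C(F)(F)F)c(O)cc2c1` reaches only the assay limit, > 20000 nM. Compound 2 `O=C(COc1ccc2cc(C(O)(C(F)(F)F)C(F)(F)F)c(O)cc2c1)Nc1ccccc1` likewise sits at the limit, > 20000 nM. Compound 4 `O=C(COc1ccc2cc(C(O)(C(F)(F)F)C(F)(F)F)c(O)cc2c1)NCc1ccccc1` has not been measured; it differs from compound 3 by benzyl in place of ((4-methylphenyl)sulfonyl)amino on an amide-type nitrogen. The measured step that touches the same nitrogen is an at least 1.2-fold lower number from compound 2 to compound 3 (0.09 log units; that floor lies within the scatter), a floor that lies within the scatter, while the step that the two limits leave unreadable from compound 1 to compound 2 cannot be read at all. Since compound 4 carries a simple phenyl-bearing group on that nitrogen, as compound 2 does, no step beyond the scatter is expected, and a limit rather than a number is quite possible. Compound 4 is therefore estimated at 22000 nM, between 9000 nM and 60000 nM, which is expected to mean a 1.4-fold higher number from compound 3 to compound 4 (0.14 log units; within the scatter).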

Compound 4, half-maximal inhibitory concentration: > 20000 nM
Compound 4: only a limit was reported; the forecaster's own chance of this, stated with the estimate: 60%; the middle value is on the limit's open side.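

In this assay compound 4, with benzyl on the amide-type nitrogen, also ends at a limit rather than a number. Putting benzyl in place of ((4-methylphenyl)sulfonyl)amino gives an at least 1.2-fold higher number from compound 3 to compound 4 (0.09 log units; that floor lies within the scatter), so this change shows no readable difference at this nitrogen. The steps from compound 1 and compound 2 to compound 4 cannot be read, and most of the series rests on one ceiling: the limit of > 20000 nM in this assay, at which 3 of the 4 values shown sit.

As far as these compounds go, whether these groups truly differ remains open. So does what a carboxylic acid or an amine carried on the amide-type nitrogen would give.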